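This account rests on a few compounds, and the source may have more. Where it says the series, first, only, none or still open, it means among the compounds named here.

Two compounds of the series have so far been run in a functional assay on DU-145 cells (Homo sapiens) for cytotoxicity, read by sulforhodamine B assay, with a stated time of 48 h; a higher number here means a weaker inhibitor, a lower number a stronger inhibitor. Compound 1 `CC(=O)OC[C@H]1O[C@@H](n2cc(Cn3cc(/C=C4/C(=O)Nc5ccc(F)cc54)c4ccccc43)nn2)[C@H](OC(C)=O)[C@@H](OC(C)=O)[C@@H]1OC(C)=O` gives 87400 nM in this assay. Compound 2 `CC(=O)OC[C@H]1O[C@@H](n2cc(CN3C(=O)/C(=C\c4ccccc4)c4ccccc43)nn2)[C@H](OC(C)=O)[C@@H](OC(C)=O)[C@@H]1OC(C)=O` gives 24100 nM, the lower of the two numbers; compound 1 sits above it by a gap beyond the usual scatter. Compound 3 `CC(=O)OC[C@H]1O[C@@H](n2cc(CN3C(=O)/C(=C\c4ccc(C)cc4)c4ccccc43)nn2)[C@H](OC(C)=O)[C@@H](OC(C)=O)[C@@H]1OC(C)=O` is not yet measured and differs from compound 2 only by methyl in place of hydrogen on an aromatic carbon, a methyl in place of hydrogen on an aromatic carbon. Going by the values given here, no measured pair isolates this change, so there is no basis for a direction. The expected step of a 1.1-fold lower number from compound 2 to compound 3 (0.04 log units; within the scatter) is none beyond the scatter. Compound 3 is therefore estimated at 22000 nM, within a range from 8000 nM to 60000 nM.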

Compound 3, half-maximal inhibitory concentration: 9400 nM
Compound 3: the middle estimate sits 2.3-fold (0.37 log units) above what was measured; the range from low to high includes it.
By their numbers in this assay, from the lowest: compound 3; then compound 2; then compound 1.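

In this assay, going by these compounds alone, methyl in place of hydrogen on the aromatic carbon para to a large group gives a 2.6-fold lower number from compound 2 to compound 3 (0.41 log units; beyond the scatter) and is the first single-place change read. The position therefore responds to substitution, with the 4-methylphenyl compound giving the lower number, though this rests on one pair and sets no trend. Nothing available bears on what lies behind the step.

Going by these compounds, whether methoxy, an amine or a carboxylic acid at this position moves the number in the same direction stays open. So does whether methyl on the other carbons of this ring does the same.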